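Shortening the Selenocyanate Arm onto the Ring

A few compounds are considered here, and "the series" means these few. Any claim that something is new, unique, unknown or untested is made for them only; others in the source may bear on it.

Compound 3 `COc1ccc(N(C)c2nc(C)nc3ccccc23)cc1C(=O)OCCCC[Se]C#N` stands lowest of the three numbers measured in a functional assay on HepG2 cells (Homo sapiens) for inhibition, read by MTT assay, with a stated time of 48 h (on this read-out higher numbers stand for weaker inhibition and lower numbers for stronger inhibition), giving 975 nM. Compound 1 `COc1ccc(N(C)c2nc(C)nc3ccccc23)cc1OCCCCC[Se]C#N` gives 5210 nM and compound 2 `COc1ccc(N(C)c2nc(C)nc3ccccc23)cc1OCCCCCC[Se]C#N` gives 4890 nM. Between them there is a 1.1-fold lower number from compound 1 to compound 2 (0.03 log units; within the scatter), so adding one carbon to the chain leaves the number within the scatter. The ester linkage, by contrast, brings a 5.3-fold lower number from compound 1 to compound 3 (0.73 log units; beyond the scatter) and a 5.0-fold lower number from compound 2 to compound 3 (0.70 log units; beyond the scatter).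

Compound 4 `COc1ccc(N(C)c2nc(C)nc3ccccc23)cc1[Se]C#N` goes further in the same direction: a group of 3 heavy atoms (1 carbon, 1 nitrogen, 1 selenium; no ring) in place of a group of 10 heavy atoms (6 carbon, 1 nitrogen, 2 oxygen, 1 selenium; no ring), on an aromatic carbon. Going by the values given here, no measured step removes the chain altogether; the steps at hand only set one linker against another or lengthen the chain by a single carbon. The step from compound 1 to compound 2 suggests that the length of the arm matters little, while the two steps into compound 3 show that the kind of linkage can shift the number by a modest amount. With the linkage gone, the feature that set compound 3 apart is lost, so the number for compound 4 is expected to drift back toward those of compound 1 and compound 2 rather than stay at the level of compound 3. The expected step is a 3.1-fold higher number from compound 3 to compound 4 (0.49 log units; beyond the scatter), carrying wide uncertainty. In this assay compound 4 is expected to give 3000 nM, within the range 800 nM to 12000 nM.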

Compound 4, half-maximal inhibitory concentration: 59 nM
Compound 4: middle estimate off by 51-fold (1.71 log units), on the high side, outside the stated range (below it).
By their numbers in this assay, from the lowest: compound 4; then compound 3; then compounds 2 and 1 (each within the scatter of the next).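

In this assay, placing the group of 3 heavy atoms directly on the aromatic carbon, ortho to a methoxy group, gives a 17-fold lower number from compound 3 to compound 4 (1.22 log units; beyond the scatter), and the comparisons with the longer ether-linked arms give an 83-fold lower number from compound 2 to compound 4 (1.92 log units; beyond the scatter) and an 88-fold lower number from compound 1 to compound 4 (1.95 log units; beyond the scatter). The earlier compounds shown here showed only that one added chain carbon stayed within the scatter and that exchanging the ether link for the ester shifted the number modestly; these new steps show that removing the arm altogether is the largest change seen at this position, and that it leaves compound 4 lowest of the four, beyond the scatter from each of the others. Nothing available here accounts for the size of this shift.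

The compounds shown jump from a direct attachment to arms of several atoms, so it remains open whether a single methylene or a two-carbon chain between the ring and the selenium would keep the number near that of compound 4. Also open, from the compounds shown here alone, is whether a thiocyanate or a plain nitrile on the same aromatic carbon would give a similar number.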